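Cyclopentyl for Butyl on a Purine-Type Scaffold

The source may report more compounds than this note shows. Statements on the series, on what has been measured and on what is new or still open speak of the compounds shown alone.

Three compounds carry a measurement in a functional assay on HepG2 cells (Homo sapiens) for antiproliferative activity, read by CCK-8 assay, with a stated time of 72 h, tested at 2 uM; a higher number here means a stronger effect of the compound at the concentration tested, a lower number a weaker effect. Compound 1 `CCCCn1cnc2c(Nc3ccccc3)nc(NCOCc3ccc(/C=C/C(=O)Nc4ccccc4N)cc3)nc21` gives 27.9% in this assay. Compound 2 `CCCCn1cnc2c(Nc3cccc(Cl)c3)nc(NCOCc3ccc(C(=O)Nc4ccccc4N)cc3)nc21` gives 30.6% in this assay, and compound 3 `Nc1ccccc1NC(=O)c1ccc(COCNc2nc(Nc3cccc(Cl)c3)c3ncn(C4CCCC4)c3n2)cc1` gives 32.6% in this assay. The difference between the core of compound 1 and the core of compound 2 is not broken down here. Compound 2 and compound 3 differ in one place only: cyclopentyl in place of butyl on an aromatic nitrogen. That change produced a number 2 percentage points higher from compound 2 to compound 3 (within the scatter).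

Compound 4 `Nc1ccccc1NC(=O)/C=C/c1ccc(COCNc2nc(Nc3ccccc3)c3ncn(C4CCCC4)c3n2)cc1` has not yet been measured in this assay. It is related to compound 1 by the same change: cyclopentyl in place of butyl on an aromatic nitrogen. Within the data shown here, the two changes sit at the same kind of place, worded identically, so the step seen from compound 2 to compound 3 is the only guide available. On that basis compound 4 is expected to show a number 2.1 percentage points higher from compound 1 to compound 4 (within the scatter), a step that stays within the scatter, because the same change gave a number 2 percentage points higher from compound 2 to compound 3 (within the scatter). The value expected for compound 4 is therefore 30%, with a plausible range from 18% to 42%.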

Compound 4, a percentage reported as inhibition, at one concentration (the size of the read-out at that concentration, not a potency): 2.93%
Estimate against measurement, compound 4: 27.1 percentage points above; the whole stated range lies above it.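

In this assay, cyclopentyl in place of butyl on an aromatic nitrogen gave a number 25 percentage points lower from compound 1 to compound 4 (beyond the scatter) and so did not repeat the earlier step, which means its effect cannot be carried from one core to another in this series as a fixed amount: the same change on two cores in this assay, a number 2 percentage points higher (within the scatter) from compound 2 to compound 3 and a number 25 percentage points lower (beyond the scatter) from compound 1 to compound 4, 27 percentage points apart, beyond the scatter of two such steps. The size of the change therefore depends on the core in these two pairs, although two pairs are too few to establish a rule for the series. They do not show which difference between the cores matters, the chlorine carried by compound 2 and compound 3 or the carbon-carbon double bond carried by compound 1 and compound 4, and they give no reason for the drop.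

Going by these compounds, it remains open whether the drop seen with cyclopentyl extends to other groups on that nitrogen on the core of compound 1, such as cyclohexyl or a longer chain ending in an amine. On these data alone, it is also open whether a core with only one of those two differences would behave like compound 3 or like compound 4.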